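The source may hold more compounds than are shown below. What is called first, only, known or untested is meant among the compounds shown, and "the series" means these compounds.

In an ADME assay on HEK-293T cells (Homo sapiens) for inhibition, read by CCK-8 assay, with a stated time of 48 h (on this read-out higher numbers stand for weaker inhibition and lower numbers for stronger inhibition), compound 1 `Cc1ccc(S(=O)(=O)Oc2ccccc2/C=C(\C#N)C(=O)Nc2nnc(C)s2)cc1` gives > 20000 nM as a limit of the assay and not a number. Compound 2 `COc1ccc(Cc2nnc(NC(=O)/C(C#N)=C/c3ccccc3OS(=O)(=O)c3ccc(OC)cc3)s2)cc1` gives > 50000 nM as a limit too. Among the compounds with values here, compound 2 therefore stands only as a limit, and the one other value shown is also a limit, so no order between the two can be read and no measured step is available for scale.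

Compound 3 `COc1ccc(Cc2nnc(NC(=O)/C(C#N)=C/c3ccccc3OS(=O)(=O)c3ccc(Cl)cc3)s2)cc1` differs from compound 2 in one place (chloro in place of methoxy on an aromatic carbon), with chloro in place of methoxy on an aromatic carbon, para to a large group. In this assay no shift beyond the usual scatter is expected, and no direction can be named from these data. The expectation rests on compound 2 with its limit of > 50000 nM and on nothing finer. The estimated step (a number no higher from compound 2 to compound 3 (the limit leaves the size open)) is expected to stay small. For compound 3 the estimated value is 50000 nM with an expected range from 20000 nM to 100000 nM and another limit as the likeliest report.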

Compound 3, half-maximal inhibitory concentration: > 50000 nM
Compound 3: only a limit was reported; the forecaster's own chance of this, stated with the estimate: 70%; the middle value lies on the limit itself.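

In this assay compound 3 gives > 50000 nM, a limit of the assay and not a number, and compound 2 also stands only as a limit, so no step between these two compounds can be read: the limit of > 50000 nM in this assay, at which 2 of the 3 values shown sit.

The compounds shown leave open how compound 2 and compound 3 would compare as numbers in this assay, and whether chloro in place of methoxy shifts the read-out at all.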